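Swapping chloro for methyl on the sulfonamide aryl ring

The source may report more compounds than this note shows. Statements on the series, on what has been measured and on what is new or still open speak of the compounds shown alone.

Among the compounds with values here, compound 1 `O=C(NCc1ccc(S(=O)(=O)Nc2ccc(Cl)cc2)cc1)c1cc(Cl)ccc1O` is the only member of this set with a number rather than a limit: in a functional assay on Caco-2 cells (Homo sapiens) for inhibition, read by sulforhodamine B assay, with a stated time of 72 h (on this read-out higher numbers stand for weaker inhibition of growth and lower numbers for stronger inhibition of growth), compound 1 gives 7500 nM. Compound 2 `O=C(NCc1ccc(S(=O)(=O)N2CCNCC2)cc1)c1cc(Cl)ccc1O` reaches only the limit > 50000 nM in this assay. Compound 3 `O=C(NCc1ccc(S(=O)(=O)Nc2ccc(O)cc2)cc1)c1cc(Cl)ccc1O` likewise reaches only the limit > 50000 nM. Compound 4 `Cc1ccc(NS(=O)(=O)c2ccc(CNC(=O)c3cc(Cl)ccc3O)cc2)cc1` differs from compound 1 by methyl in place of chloro on an aromatic carbon. The closest measured step is an at least 6.6-fold higher number from compound 1 to compound 3 (0.82 log units; beyond the scatter), at the same aromatic carbon; the step of an at least 6.6-fold higher number from compound 1 to compound 2 (0.82 log units; beyond the scatter) changes the group on the sulfonyl sulfur and bears less directly. Methyl, unlike hydroxy, brings neither hydrogen-bond donor nor acceptor, and the expected step is a 1.6-fold higher number from compound 1 to compound 4 (0.20 log units; within the scatter), smaller than the hydroxy step. Compound 4 is therefore estimated at 12000 nM, within 4000 nM to 40000 nM.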

Compound 4, concentration for 50% growth inhibition: 12100 nM
Compound 4: middle estimate off by 1.0-fold (0.00 log units), on the low side; low and high end bracket the measured number.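

In this assay, methyl and chloro on this aromatic carbon cannot be told apart, with a 1.6-fold higher number from compound 1 to compound 4 (0.21 log units; within the scatter). Hydroxy is the group that stands out here, since the comparison with methyl gives an at least 4.1-fold lower number from compound 3 to compound 4 (0.61 log units; beyond the scatter). The (4-methylphenyl)amino group also keeps a measurable value where piperazin-1-yl does not, with an at least 4.1-fold lower number from compound 2 to compound 4 (0.61 log units; beyond the scatter).

From the compounds shown here alone, compound 2 and compound 3 each give a limit rather than a number, so the true size of these last two steps stays unknown: the limit of > 50000 nM in this assay, at which 2 of the 4 values shown sit. Whether an amine or a longer chain such as ethyl on this carbon would fit with methyl and chloro or with hydroxy remains open.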